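A few compounds are considered here, and "the series" means these few. Any claim that something is new, unique, unknown or untested is made for them only; others in the source may bear on it.

Working notes on the thiourea series. In a functional assay on B16-F10 cells (Mus musculus) for cytotoxicity, read by MTT assay, with a stated time of 48 h (on this read-out lower numbers stand for stronger inhibition and higher numbers for weaker inhibition), compound 1 `Fc1ccc(NC(=S)Nc2nc3ccccc3s2)cc1` reaches only the limit of the read-out, > 50000 nM. Compound 2 `Fc1ccc(NC(=S)Nc2nc3ccc(F)cc3s2)cc1`, which carries fluoro in place of hydrogen on an aromatic carbon, gives 47700 nM in this assay, and the step of an at least 1.0-fold lower number from compound 1 to compound 2 (0.02 log units; that floor lies within the scatter) is no more than a change from a limit to a number at its edge. Compound 3 `c1ccc2sc(Nc3nc4ccccc4s3)nc2c1`, a diaryl amine without the thiourea, again sits at the limit, > 50000 nM. Compound 2 thus stands as the only number shown, with the other two entries sitting at the limit of > 50000 nM in this assay, at which 2 of the 3 values shown sit.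

Compound 4 `Fc1ccc2nc(NC(=S)Nc3ccccc3)sc2c1` differs from compound 2 by hydrogen in place of fluoro on an aromatic carbon; read one bond further out, 4-fluorophenyl becomes phenyl. Among the compounds with values here, the only measured step that bears on it, fluoro entering on an aromatic carbon from compound 1 to compound 2, lay within the scatter, so removing a fluoro from another aromatic carbon is expected to stay within the scatter as well, with a real chance that only a limit is returned. The expected step is a 1.0-fold higher number from compound 2 to compound 4 (0.02 log units; within the scatter). Compound 4 is expected at 50000 nM, between 25000 nM and 100000 nM.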

Compound 4, half-maximal inhibitory concentration: > 50000 nM
Compound 4 was reported as a limit; the forecaster's own chance of this, stated with the estimate: 60%; the middle value sits exactly at the limit.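

Within the data shown here, this is the first change at the 4-fluorophenyl group, as the earlier fluoro step concerned a different aromatic carbon. In this assay the step reads an at least 1.0-fold higher number from compound 2 to compound 4 (0.02 log units; that floor lies within the scatter), so replacing this fluoro with hydrogen gives no change that can be told from the scatter, and compound 4 is a limit rather than a number, so only the floor of the step can be read. The series now rests almost entirely on one boundary: the limit of > 50000 nM in this assay, at which 3 of the 4 values shown sit.

As far as these compounds go, it remains open whether an amine, a carboxylic acid or a methoxy group in place of this fluoro would give a number clear of that limit. From the compounds shown here alone, how far compound 1, compound 3 and compound 4 lie beyond the limit also stays unknown, so they cannot be ranked.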